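This account rests on a few compounds, and the source may have more. Where it says the series, first, only, none or still open, it means among the compounds named here.

Compound 1, `Cc1occc1-c1nnc2n1NC(c1ccco1)S2`, gives 24.1%.
Compound 2, `Cc1occc1-c1nnc2n1NC(c1ccc[nH]1)S2`, gives 20.3%.

Both compounds were tested in a functional assay on the whole organism (strain Wistar Albino) for inhibition, with Rattus norvegicus as the target, read by paw edema, with a stated time of 3 h, at a dose of 20 mg/kg; on this read-out lower numbers stand for less inhibition and higher numbers for more inhibition at the one dose given (going by the name of the read-out). Within the data shown here, compound 2 sits at 20.3%, and the only other number, that of compound 1, lies within the scatter of it: the step of a number 3.8 percentage points lower from compound 1 to compound 2 (within the scatter) is too small to count as a real difference.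

Compound 3 is `Cc1occc1-c1nnc2n1NC(c1cccn1C)S2`, which has not yet been tested. It differs from compound 2 by methyl in place of hydrogen on an aromatic nitrogen. Among the measured compounds shown here, the one measured step, from compound 1 to compound 2, changed the group sitting on the saturated ring carbon of the shared core and produced no movement beyond the scatter. It does not speak directly to adding a methyl on the aromatic nitrogen of that five-membered ring, so nothing measured here points to a shift in either direction. The expected step is therefore a number 1.7 percentage points higher from compound 2 to compound 3 (within the scatter), which is none beyond the scatter. Compound 3 is estimated to give 22% in this assay, with a likely range from 10% to 34%.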

Compound 3, a percentage reported as inhibition, in the whole organism at one dose (the size of the read-out at that dose, not a potency): 21.5%
The estimate for compound 3 lay 0.5 percentage points above the measured number; the range from low to high includes it.
By their numbers in this assay, from the lowest: compounds 2, 3 and 1 (each within the scatter of the next).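

In this assay, 1H-pyrrol-2-yl and 1-methyl-1H-pyrrol-2-yl cannot be told apart, with methyl in place of hydrogen on the aromatic nitrogen giving a number 1.2 percentage points higher from compound 2 to compound 3 (within the scatter). The hydrogen on that nitrogen is therefore not needed to keep the number in this range, and a single added carbon there, next to the ring atom that bears a large group, gives no difference that can be read. Compared directly with the furan-2-yl group, the 1-methyl-1H-pyrrol-2-yl group gives a number 2.6 percentage points lower from compound 1 to compound 3 (within the scatter), so all three groups on the saturated ring carbon now lie within the scatter of one another, and nothing available explains this result.

The compounds shown leave open whether this nitrogen accepts something larger than methyl, such as a longer chain like n-butyl, a benzyl group, or a chain ending in an amine or a carboxylic acid. They also leave open whether a group of another kind on the saturated ring carbon, such as phenyl, would move the number beyond the scatter, since the three groups seen so far are all closely related five-membered aromatic rings.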